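Chloro for methoxy on a chalcone-linked imidazolone series

The source may report more compounds than this note shows. Statements on the series, on what has been measured and on what is new or still open speak of the compounds shown alone.

Measured so far:
compound 1, `COc1cc(/C=C/C(=O)c2cccc(-n3cc(-c4ccc(Cl)cc4)[nH]c3=O)c2)cc(OC)c1OC`, 13800 nM
compound 2, `COc1ccc(-c2cn(-c3cccc(C(=O)/C=C/c4ccc(O)c(OC)c4)c3)c(=O)[nH]2)cc1`, 5250 nM
compound 3, `COc1ccc(-c2cn(-c3cccc(C(=O)/C=C/c4cc(OC)c(OC)c(OC)c4)c3)c(=O)[nH]2)cc1`, 5480 nM

Of the compounds shown here, three have been tested in a functional assay on MDA-MB-231 cells (Homo sapiens) for inhibition; a higher number here means a weaker inhibitor of growth, a lower number a stronger inhibitor of growth. Compound 2 and compound 3 differ in their cores: 4-hydroxy-3-methoxyphenyl in place of 3,4,5-trimethoxyphenyl on a double-bonded chain carbon bound to a double-bonded chain carbon. That change shows a 1.0-fold higher number from compound 2 to compound 3 (0.02 log units; within the scatter), so compound 2 and compound 3 are not told apart by this assay. Compound 3 and compound 1 differ by chloro in place of methoxy on an aromatic carbon, and there the assay records a 2.5-fold higher number from compound 3 to compound 1 (0.40 log units; beyond the scatter).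

Compound 4, `COc1cc(/C=C/C(=O)c2cccc(-n3cc(-c4ccc(Cl)cc4)[nH]c3=O)c2)ccc1O`, has not yet been measured. It differs from compound 2 by chloro in place of methoxy on an aromatic carbon; the place is the same as in the change from compound 3 to compound 1, so this is the same change made on the other core. Going by the values given here, because a 2.5-fold higher number from compound 3 to compound 1 (0.40 log units; beyond the scatter) is the only record of this change, compound 4 is expected to give a number about a 2.4-fold higher number from compound 2 to compound 4 (0.38 log units; beyond the scatter) in this assay, starting from compound 2 at 5250 nM. On that basis compound 4 is estimated at 12500 nM, expected to lie between 5000 nM and 30000 nM.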

Compound 4, concentration for 50% growth inhibition: 3870 nM
Estimate against measurement, compound 4: 3.2-fold (0.51 log units) above, outside the stated range (below it).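

On the core of compound 2, replacing 4-methoxyphenyl with 4-chlorophenyl gives a 1.4-fold lower number from compound 2 to compound 4 (0.13 log units; within the scatter) in this assay, and the assay does not tell these two compounds apart. Set beside the earlier step, the same change does not carry over unchanged from one core to the other: the same change on two cores in this assay, a 2.5-fold higher number (0.40 log units; beyond the scatter) from compound 3 to compound 1 and a 1.4-fold lower number (0.13 log units; within the scatter) from compound 2 to compound 4, 3.4-fold (0.53 log units) apart, beyond the scatter of two such steps. The change lowers growth inhibition beyond the scatter with the 3,4,5-trimethoxyphenyl group in place, but has no resolved effect with the 4-hydroxy-3-methoxyphenyl group; this comparison rests on a single pair for each core, and it does not show which feature of the two cores accounts for the gap or how the change would behave on a further core.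

The compounds shown leave open whether a fluoro, a methyl or an amine at the same place would follow the pattern of either core. They also leave open whether a chalcone aryl group carrying a carboxylic acid would respond to the chloro for methoxy change in the same way as either core.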